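Swapping a propyl for a tert-butyl on the outer ring

The source may report more compounds than this note shows. Statements on the series, on what has been measured and on what is new or still open speak of the compounds shown alone.

In an assay on isolated protein for inhibition of Rho-associated protein kinase 1 (Homo sapiens), read by scintillation counting, radiometric assay and 33P incorporation, with a stated time of 40 min, in the presence of a further agent that is not named here (a higher number here means a weaker inhibitor, a lower number a stronger inhibitor), compound 1 `CCCC(=O)Nc1cccc(NC(=O)COc2ccc3c(=O)ccoc3c2)c1` gives 1430 nM. Within the data shown here, compound 2 `CCCc1ccc(C(=O)Nc2cccc(NC(=O)COc3ccc4c(=O)ccoc4c3)c2)cc1` gives 143 nM in this assay, and the single change between them brought a 10-fold lower number from compound 1 to compound 2 (1.00 log units; beyond the scatter). Among the two numbers measured so far, compound 2 stands lowest, its nearest neighbour being compound 1.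

Compound 3 `CC(C)(C)c1ccc(C(=O)Nc2cccc(NC(=O)COc3ccc4c(=O)ccoc4c3)c2)cc1` differs from compound 2 by tert-butyl in place of propyl on an aromatic carbon. Among the measured compounds shown here, the only measured step exchanged a propyl for a 4-propylphenyl on the carbonyl carbon, a different kind of change, so nothing measured speaks directly to replacing one small alkyl by another on the outer ring. The expected step is therefore small, a 1.0-fold higher number from compound 2 to compound 3 (0.02 log units; within the scatter), with no clear direction. Compound 3 is estimated at 150 nM in this assay, within a range from 60 nM to 400 nM.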

Compound 3, half-maximal inhibitory concentration: 165 nM
The estimate for compound 3 lay 1.1-fold (0.04 log units) below the measured number, and the stated range covers the measured number.
By their numbers in this assay, from the lowest: compounds 2 and 3 (each within the scatter of the next); then compound 1.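

In this assay, the change to tert-butyl on the aromatic carbon gives a 1.2-fold higher number from compound 2 to compound 3 (0.06 log units; within the scatter), so this position takes the branched group and the straight propyl chain without a difference that can be read. The advantage seen earlier over the small propyl on the carbonyl carbon also survives with the new group, with an 8.7-fold lower number from compound 1 to compound 3 (0.94 log units; beyond the scatter), so that step does not depend on a propyl on the aromatic ring. No measurement shown here bears on why the two groups read alike.

Both groups at this position contain carbon only, which leaves open what an amine or a carboxylic acid on the same aromatic carbon would do. On these data alone, it is also open whether a longer chain, such as hexyl, would fit as well as tert-butyl and propyl do.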